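The source may hold more compounds than are shown below. What is called first, only, known or untested is meant among the compounds shown, and "the series" means these compounds.

Of the compounds shown here, two have been measured so far in a functional assay on MCF7 cells (Homo sapiens) for cytotoxicity, read by MTT assay, with a stated time of 48 h (on this read-out higher numbers stand for weaker inhibition of growth and lower numbers for stronger inhibition of growth), on this series. There compound 1 (`OC[C@H]1O[C@@H](n2cnc3cc(F)c(F)cc32)[C@H](O)[C@@H]1O`) gives 57900 nM and compound 2 (`CC(C)n1c(C(F)(F)F)nc2cc(Cl)c(Cl)cc21`) gives 70500 nM on the same read-out. These two values lie within the usual scatter of each other, so compound 2 stands level with compound 1 on the numbers shown and neither can be ranked. Compound 3 (`FC(F)(F)c1nc2cc(Cl)c(Cl)cc2n1Cc1ccccc1`) departs from compound 2 at a single place, with benzyl in place of isopropyl on an aromatic nitrogen, next to the ring atom that bears a trifluoromethyl group (benzyl in place of isopropyl on an aromatic nitrogen). For the measured compounds named here, no measured pair in this small set shows what such a change does, so any forecast rests on compound 2 at 70500 nM alone. A modest step toward stronger inhibition of growth is nevertheless expected in this assay and its size is estimated as a 2.4-fold lower number from compound 2 to compound 3 (0.37 log units; beyond the scatter) with wide uncertainty. In this assay the estimate for compound 3 is 30000 nM and it is expected to fall between 9000 nM and 90000 nM.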

Compound 3, concentration for 50% growth inhibition: 8700 nM
Beside the measured number, compound 3's estimate is 3.4-fold (0.54 log units) above it; measured number below the stated range.
By their numbers in this assay, from the lowest: compound 3; then compounds 1 and 2 (each within the scatter of the next).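

In this assay, the aromatic nitrogen, next to the ring atom that bears a trifluoromethyl group, turns out to be a place where the choice of group changes the read-out: benzyl in place of isopropyl gives an 8.1-fold lower number from compound 2 to compound 3 (0.91 log units; beyond the scatter), a step toward stronger inhibition of growth. For the compounds shown here, this is the first pair that differs in one place, so it is also the first direct reading of any single change on this core. It shows that this nitrogen accepts a group carrying a six-membered aromatic ring of carbon only, and that the growth inhibition is stronger with that group than with isopropyl. Nothing measured on these groups accounts for the step.

Going by these compounds, a single step cannot separate the aromatic ring from the larger size of the group, so it remains open whether a cyclohexylmethyl group or a longer chain such as n-butyl would do the same. The compounds shown also leave open how a phenethyl group, or a benzyl ring carrying a methoxy group or an amine, would behave at this nitrogen.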